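The source may hold more compounds than are shown below. What is called first, only, known or untested is meant among the compounds shown, and "the series" means these compounds.

Measured so far in an assay on membranes from cerebellum for inhibition of Monoglyceride lipase (Rattus norvegicus), tested at 100 uM; on this read-out higher numbers stand for more inhibition at the one concentration tested (going by the name of the read-out) and lower numbers for less inhibition:

Compound 1 `O=C(OCC1CO1)c1ccccc1-c1ccccc1` gives 18%.
Compound 2 `O=C(OCC1CO1)c1ccccc1` gives 0.2%.
Compound 3 `CCCCC/C=C\C/C=C\CCCCCCCC(=O)OCC1CCCCO1` gives 38%.

Compound 2 stands lowest of the three numbers in this assay; compound 1 lies above it beyond the scatter, and compound 3 lies furthest above it, also beyond the scatter. The unmeasured compound 4 `O=C(OCC1CO1)c1ccc(-c2ccccc2)cc1` is derived from compound 2 by a single change: phenyl in place of hydrogen on an aromatic carbon.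

Going by the values given here, only one measured step bears on this change. It is a number 17.8 percentage points lower from compound 1 to compound 2 (beyond the scatter), the removal of a phenyl from the shared core, which cost a modest amount of inhibition. Compound 4 reintroduces a phenyl, though at a different aromatic carbon than in compound 1, so the direction is taken from that step while its size is uncertain. A modest rise beyond the scatter is therefore expected, a number 14.8 percentage points higher from compound 2 to compound 4 (beyond the scatter). Compound 4 is estimated to give 15% in this assay, within a range from 0% to 35%.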

Compound 4, a percentage reported as inhibition, at one concentration (the size of the read-out at that concentration, not a potency): 9%
Compound 4: the middle estimate sits 6 percentage points above what was measured; low and high end bracket the measured number.
By their numbers in this assay, from the lowest: compounds 2, 4 and 1 (each within the scatter of the next, the first and the last beyond it); then compound 3.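

In this assay, phenyl in place of hydrogen on an aromatic carbon, para to a group of 7 heavy atoms, gives a number 8.8 percentage points higher from compound 2 to compound 4 (within the scatter), so at this position the change does not separate compound 4 from compound 2. The earlier step, a number 17.8 percentage points lower from compound 1 to compound 2 (beyond the scatter), lay beyond the scatter, so a phenyl on the shared core does not give a step beyond the scatter at both of the places shown. Nothing measured here accounts for this difference between the two steps.

From the compounds shown here alone, what remains open is whether a group other than phenyl at this place, such as an amine, a carboxylic acid or a longer chain, would give a step beyond the scatter. Also open, going by these compounds, is whether a second phenyl on the core of compound 4 would do so.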